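This account rests on a few compounds, and the source may have more. Where it says the series, first, only, none or still open, it means among the compounds named here.

Three compounds share one core and differ only in the group carried on an amine nitrogen in a ring. Compound 1 `CN(C)CCN1CCN(c2nc(-c3ccccn3)nc3c2CN(S(=O)(=O)c2ccccc2)CC3)CC1` carries phenylsulfonyl there; in an assay on cells with Cystic fibrosis transmembrane conductance regulator variant F508del (Homo sapiens) as the target, read by fluorescence, with stated times of 24 h and 30 min (on this read-out lower numbers stand for an effect already at smaller amounts and higher numbers for an effect only at larger amounts of compound), compound 1 gives 100000 nM. Compound 2 `CN(C)CCN1CCN(c2nc(-c3ccccn3)nc3c2CN(C(=O)c2ccccc2)CC3)CC1` carries benzoyl, and in this assay compound 2 gives 100000 nM. Compound 3 `CN(C)CCN1CCN(c2nc(-c3ccccn3)nc3c2CN(Cc2ccc(F)cc2)CC3)CC1` carries 4-fluorobenzyl, and in this assay compound 3 gives 100000 nM. Compound 3 thus stands level with compounds 1 and 2 at the digits shown. The three steps among them read no change at the digits printed from compound 1 to compound 2 (within the scatter), no change at the digits printed from compound 1 to compound 3 (within the scatter) and no change at the digits printed from compound 2 to compound 3 (within the scatter); none of them moves the read-out.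

Compound 4 `COc1ccc(CN2CCc3nc(-c4ccccn4)nc(N4CCN(CCN(C)C)CC4)c3C2)cc1` is not yet measured. It differs from compound 3 by methoxy in place of fluoro on an aromatic carbon. Among the compounds with values here, no measured step exchanges a substituent on this aromatic ring; none bears directly on the change. The steps that do exist exchange the whole group on the ring nitrogen and leave the value unchanged. The account therefore expects no shift beyond the scatter in this assay, which is an expected step of no change at the digits printed from compound 3 to compound 4 (within the scatter). Compound 4 is estimated to give 100000 nM in this assay, with an expected range from 50000 nM to 100000 nM.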

Compound 4, half-maximal effective concentration: 100000 nM
For compound 4 middle estimate and measured number coincide at the digits printed; low and high end bracket the measured number.
By their numbers in this assay, from the lowest: compounds 1, 2, 3 and 4 (each within the scatter of the next).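

The exchange of fluoro for methoxy is the first change shown on the aromatic ring itself, at the place para to a large group rather than on the ring nitrogen, and in this assay it gives no change at the digits printed from compound 3 to compound 4 (within the scatter). The 4-methoxybenzyl group also joins the set compared on the amine nitrogen, with no change at the digits printed from compound 2 to compound 4 (within the scatter) when it stands in place of benzoyl and no change at the digits printed from compound 1 to compound 4 (within the scatter) when it stands in place of phenylsulfonyl, so the read-out stays level across both a substituent exchange on the ring and four different groups on that nitrogen. No evidence on hand bears on why the read-out stays level.

Since all four compounds share one value, with compound 4 at 100000 nM, these compounds cannot tell whether any group at this position can move the read-out on the shared core. On these data alone, it remains open whether an amine or a carboxylic acid in place of methoxy, a longer chain in place of the 4-methoxybenzyl group, or a different chain in place of the dimethylaminoethyl group would give a lower number in this assay.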